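Removing the nitro group: what compound 3 should show

The source may report more compounds than this note shows. Statements on the series, on what has been measured and on what is new or still open speak of the compounds shown alone.

Going by the values given here, in a functional assay on A-375 cells (Homo sapiens) for inhibition (on this read-out lower numbers stand for stronger inhibition and higher numbers for weaker inhibition), compound 2 `N#CC1CN1C(=O)Nc1ccc([N+](=O)[O-])cc1` gives 3900 nM, the higher of the two numbers measured so far. Among the compounds with values here, its nearest neighbour, compound 1 `N#CC1CN1C(=O)Nc1ccc(F)cc1`, gives 3400 nM in this assay, and the one measured step, a 1.1-fold higher number from compound 1 to compound 2 (0.06 log units; within the scatter), shows that exchanging fluoro for nitro on the aromatic carbon left the read-out within the scatter. Compound 3 `N#CC1CN1C(=O)Nc1ccccc1` has not yet been measured in this assay. It differs from compound 2 in a single place: hydrogen in place of nitro on an aromatic carbon. Within the data shown here, the only measured step that bears on this change is a 1.1-fold higher number from compound 1 to compound 2 (0.06 log units; within the scatter), in which two different substituents at this place gave numbers that cannot be told apart. Since neither fluoro nor nitro moved the number beyond the scatter, removing the nitro altogether is expected to leave the read-out close to where compound 2 stands, with no step beyond the scatter in either direction. Compound 3 is therefore estimated to give 3500 nM in this assay, with a range from 1500 nM to 8000 nM. The expected step, a 1.1-fold lower number from compound 2 to compound 3 (0.05 log units; within the scatter), is estimated to be small.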

Compound 3, half-maximal inhibitory concentration: 11000 nM
Beside the measured number, compound 3's estimate is 3.1-fold (0.50 log units) below it; measured number above the stated range.
By their numbers in this assay, from the lowest: compounds 1 and 2 (each within the scatter of the next); then compound 3.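

The position is not indifferent to what it carries: in this assay, going a 2.8-fold higher number from compound 2 to compound 3 (0.45 log units; beyond the scatter) and going a 3.2-fold higher number from compound 1 to compound 3 (0.51 log units; beyond the scatter) are both steps beyond the scatter, so losing the substituent raises the number whichever of the two groups is removed. Going by these compounds alone, the earlier comparison of fluoro with nitro showed only that these two groups cannot be told apart at this place on the aromatic ring; it could not show that either of them differs from hydrogen, and the new steps now show that both do. Among these three compounds, compound 3, with hydrogen at this place, is the weakest inhibitor, but the data given here offer no measurement that explains why fluoro and nitro match each other or why hydrogen falls away from both.

What the compounds shown leave open is whether any substituent at this place would bring the number down to the level of compound 1 and compound 2, or only certain ones, as a methyl group, a methoxy group, an amine or a carboxylic acid could test. They also leave open whether a group stronger than fluoro or nitro exists for this place at all, since neither of those two moves the number far from the other.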